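Swapping a thiazole arm for plain phenyl

A few compounds are considered here, and "the series" means these few. Any claim that something is new, unique, unknown or untested is made for them only; others in the source may bear on it.

Measured in a functional assay on MCF7 cells (Homo sapiens) for antiproliferative activity, read by MTT assay, with a stated time of 48 h; a higher number here means a weaker inhibitor, a lower number a stronger inhibitor:
Compound 1 `CC(=O)Oc1c(Br)cc(Br)cc1/C=C1\N=C(c2ccccc2)N(c2ncc(-c3ccccc3)s2)NC1=O`: 38300 nM
Compound 2 `COc1cc(C2=N/C(=C\c3cc(Br)cc(Br)c3OC(C)=O)C(=O)NN2c2ncc(-c3ccccc3)s2)cc(OC)c1OC`: 410 nM

Of these two, compound 2 has the lower number and is therefore the stronger inhibitor. The next compound to be tested, compound 3 `COc1cc(C2=N/C(=C\c3cc(Br)cc(Br)c3OC(C)=O)C(=O)NN2c2ccccc2)cc(OC)c1OC`, has phenyl in place of 5-phenyl-1,3-thiazol-2-yl on an amine nitrogen in a ring.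

Within the data shown here, the only measured step, a 93-fold lower number from compound 1 to compound 2 (1.97 log units; beyond the scatter), is large, but it changed a different group, so it gives no direct guide to this position. It does show that a single swap moved the number a long way in this assay. Among the measured compounds shown here, with compound 2 at 410 nM, the lowest number so far, a rise is expected to be likelier than a fall. The expected change is a 3.7-fold higher number from compound 2 to compound 3 (0.56 log units; beyond the scatter), a moderate weakening with wide uncertainty. For compound 3, the estimated value is 1500 nM, with an expected range of 250 nM to 10000 nM.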

Compound 3, half-maximal inhibitory concentration: 350 nM
For compound 3 the middle estimate is 4.3-fold (0.63 log units) above the measured one; low and high end bracket the measured number.
By their numbers in this assay, from the lowest: compounds 3 and 2 (each within the scatter of the next); then compound 1.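

In this assay, putting phenyl in place of 5-phenyl-1,3-thiazol-2-yl on the amine nitrogen in a ring gives a 1.2-fold lower number from compound 2 to compound 3 (0.07 log units; within the scatter) and so compound 2 and compound 3 cannot be told apart. At this position, then, a group of 11 heavy atoms with two aromatic rings and 2 hydrogen-bond acceptors reads the same as one of 6 heavy atoms with one aromatic ring and 0 acceptors, something the earlier step, made at a different place, could not show. Nothing at hand explains why these two groups read alike.

As far as these compounds go, whether a much smaller group such as methyl, or a phenyl bearing an amine or a carboxylic acid, would read the same on this nitrogen stays open. Also open, from the compounds shown here alone, is whether this match would hold with the plain phenyl of compound 1 in place of 3,4,5-trimethoxyphenyl.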